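Nitro for methoxy on a sulfonamide-bearing pyridinone series

The compounds below may be only part of what the source reports. "The series", "measured", "known", "first", "only" and "open" are said of these compounds alone.

Compound 1 `C/C(=N\NC(=O)CC#N)c1ccc(NS(=O)(=O)c2ccc(C)cc2)cc1` gives 26000 nM in a functional assay on HepG2 cells (Homo sapiens) for cytotoxicity, read by sulforhodamine B assay, with a stated time of 48 h; a higher number here means a weaker inhibitor, a lower number a stronger inhibitor.
Compound 2 `COc1ccc(-c2c(C#N)c(N)n(/N=C(/C)c3ccc(NS(=O)(=O)c4ccc(C)cc4)cc3)c(=O)c2C#N)cc1` gives 31800 nM in this assay.
Compound 3 `Cc1ccc(S(=O)(=O)Nc2ccc(-c3cc(-c4ccc([N+](=O)[O-])cc4)n(-c4ccccc4)n3)cc2)cc1` gives "not active" (no number reported) in this assay, and no number was given for it.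

Of the two compounds with a number, compound 2 has the higher one, but its nearest neighbour, compound 1, lies within the usual scatter of it, so the two cannot be told apart on this evidence. Compound 3 offers no number to compare. All three share the toluenesulfonamide-bearing aryl hydrazone motif; compound 2 carries, in addition, the larger cyano-substituted pyridinone core with a 4-methoxyphenyl arm.

The unmeasured compound 4 `C/C(=N/n1c(N)c(C#N)c(-c2ccc([N+](=O)[O-])cc2)c(C#N)c1=O)c1ccc(NS(=O)(=O)c2ccc(C)cc2)cc1` keeps the core of compound 2 and differs from it in one place: nitro in place of methoxy on an aromatic carbon

Among the measured compounds shown here, no measured pair in this set shows what such an exchange does here, so the expected step from compound 2 to compound 4 in this assay is, in its direction, open; the most likely outcome is a step that stays within the scatter, with no firm lean either way. On that basis compound 4 is estimated to give about 35000 nM in this assay, with a plausible range from 12000 nM to 100000 nM, which means an expected step of a 1.1-fold higher number from compound 2 to compound 4 (0.04 log units; within the scatter).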

Compound 4, half-maximal inhibitory concentration: 31500 nM
The estimate for compound 4 lay 1.1-fold (0.05 log units) above the measured number; the measured number falls inside the stated range.
By their numbers in this assay, from the lowest: compounds 1, 4 and 2 (each within the scatter of the next).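

Among the compounds shown here, the exchange of methoxy for nitro, 4-methoxyphenyl to 4-nitrophenyl on the shared core, gives the first direct reading at this position: in this assay the step is a 1.0-fold lower number from compound 2 to compound 4 (0.00 log units; within the scatter). Compound 2 and compound 4 therefore cannot be told apart in this cell read-out, although the two groups differ in their heavy atoms and in their counted hydrogen-bond acceptors, so for this one pair that difference leaves no readable mark on the number. No measurement of any property of these compounds is available to explain this result.

Going by these compounds, only these two groups have been compared at this position, so it remains open whether an amine, a carboxylic acid, a halogen such as chlorine or a longer alkoxy chain would also stay within the scatter of compound 2. On these data alone, it is also open whether the same exchange of methoxy for nitro would read the same way on a different core, since this single pair speaks only for the core of compound 2.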